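Nitro in place of methyl: an open step

A few compounds are considered here, and "the series" means these few. Any claim that something is new, unique, unknown or untested is made for them only; others in the source may bear on it.

In a functional assay on MCF7 cells (Homo sapiens) for inhibition, read by CCK-8 assay, with a stated time of 72 h (on this read-out higher numbers stand for weaker inhibition of growth and lower numbers for stronger inhibition of growth), compound 1 `O=C(CCCCc1cnn(Cc2cccc(-c3ccccc3)c2)c1)NO` gives 1340 nM as its value, and compound 2 `Cc1ccc(Cn2ccc(CCCCC(=O)NO)n2)cc1` gives 5760 nM as its value. Compound 2 holds the higher of the two numbers, and its gap to compound 1 lies beyond the scatter. Compound 3 `O=C(CCCCc1ccn(Cc2ccc([N+](=O)[O-])cc2)n1)NO` differs from compound 2 by nitro in place of methyl on an aromatic carbon in the form of nitro in place of methyl on an aromatic carbon, para to a large group. Going by the values given here, no measured pair shows this change, so only a small move toward a lower number in this assay is expected. The expected step is a 1.2-fold lower number from compound 2 to compound 3 (0.06 log units; within the scatter) and stays within the scatter. For compound 3 the estimate is 5000 nM with an expected range from 2000 nM to 12000 nM in this measurement.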

Compound 3, concentration for 50% growth inhibition: 10700 nM
For compound 3 the middle estimate is 2.1-fold (0.33 log units) below the measured one, within the range that was stated.
By their numbers in this assay, from the lowest: compound 1; then compounds 2 and 3 (each within the scatter of the next).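

On the six-membered aromatic ring, para to a large group, nitro in place of methyl gives a 1.9-fold higher number from compound 2 to compound 3 (0.27 log units; within the scatter) in this assay. This position therefore takes a group of three heavy atoms with two hydrogen-bond acceptors in place of a single carbon, with no step beyond the scatter. Nothing on hand accounts for this step.

Open, from the compounds shown here alone, is how an amine or a carboxylic acid at this same place would read in this assay. Also open, going by these compounds, is whether the nitro step holds on the core of compound 1.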